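A few compounds are considered here, and "the series" means these few. Any claim that something is new, unique, unknown or untested is made for them only; others in the source may bear on it.

Measured so far in an assay on isolated protein for inhibition of Calpain-1 catalytic subunit (Sus scrofa), read by FRET; on this read-out higher numbers stand for weaker inhibition and lower numbers for stronger inhibition:
compound 1 `O=C(O)/C(S)=C/c1c[nH]c2cc(Br)ccc12` gives 7 nM
compound 2 `O=C(O)/C(S)=C/c1c[nH]c2cc(Cl)ccc12` gives 210 nM
compound 3 `O=C(O)/C(S)=C/c1cccc(F)c1` gives 19000 nM

Compound 2 stands second highest of the three numbers in this assay. Its nearest neighbour is compound 1, which gives a lower number; the step of a 30-fold higher number from compound 1 to compound 2 (1.48 log units; beyond the scatter) is large and beyond the scatter. Going by the values given here, compound 3, built on a different core and carrying a fluoro, gives the highest number of the three; no single-point step joins it to compound 2, so its value can only be noted beside the others.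

Compound 4 `O=C(O)/C(S)=C/c1c[nH]c2cc(F)ccc12` is not yet measured. The change from compound 2 is fluoro in place of chloro on an aromatic carbon. Among the compounds with values here, the only measured step that bears on this change is a 30-fold higher number from compound 1 to compound 2 (1.48 log units; beyond the scatter), where the halogen at the same place was exchanged and the number rose by a large margin. Continuing from chloro to fluoro, a further rise of the number in this assay is expected, beyond the scatter, although the size of that rise is not fixed by any second step among the measured compounds. The expected step is a 7.1-fold higher number from compound 2 to compound 4 (0.85 log units; beyond the scatter). Compound 4 is therefore estimated at 1500 nM, with a range from 300 nM to 8000 nM.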

Compound 4, half-maximal inhibitory concentration: 10 nM
Beside the measured number, compound 4's estimate is 150-fold (2.18 log units) above it; measured number outside the range, below it.
By their numbers in this assay, from the lowest: compounds 1 and 4 (each within the scatter of the next); then compound 2; then compound 3.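

In this assay, the halogen on the six-membered aromatic ring of the shared core does not behave as a graded series, since the step to fluoro (a 21-fold lower number from compound 2 to compound 4 (1.32 log units; beyond the scatter)) runs against the earlier step to chloro (a 30-fold higher number from compound 1 to compound 2 (1.48 log units; beyond the scatter)) and does not extend it. Compound 2, the chloro member, is the one that stands apart, while fluoro and bromo at this place cannot be told apart (a 1.4-fold higher number from compound 1 to compound 4 (0.15 log units; within the scatter)), so the number does not move in one direction along fluoro, chloro and bromo. Nothing available accounts for the departure of the chloro compound from the other two.

Three halogens at one place cannot show whether the value of compound 2 is a lone exception or whether fluoro and bromo mark the usual level, and a methyl, methoxy, nitrile or amine group at the same carbon would be needed to show whether a halogen is required there at all. Also open, going by these compounds, is whether the same order of halogens holds at another carbon of that ring, and whether the thiol or the carboxylic acid of the shared core can be exchanged, for instance for an amide.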